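The compounds below may be only part of what the source reports. "The series", "measured", "known", "first", "only" and "open" are said of these compounds alone.

Compound 1, `COc1cccc(-c2ccc3ccc(C)nc3c2)c1` — 860 nM
Compound 2, `Cc1ccc2ccc(-c3ccccc3C#N)cc2n1` — 9800 nM
Compound 3, `Cc1ccc2ccc(-c3cc(Cl)cc(C#N)c3)cc2n1` — 1.4 nM

These three compounds share one core and were measured in a functional assay on CHO cells for inhibition of metabotropic glutamate receptor 5 (Rattus norvegicus), read by FLIPR and calcium flux; a higher number here means a weaker inhibitor, a lower number a stronger inhibitor. Compound 3 stands at the lowest number of the three, which here means the strongest inhibitor: its nearest neighbour is compound 1, whose value is far higher, beyond the scatter, and compound 2 lies further still. Compounds 1 and 2 show that the ring attached to the core, and what sits on it, decides much of the result.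

Compound 4, `Cc1ccc2ccc(-c3cc(O)cc(C#N)c3)cc2n1`, has not yet been measured. It differs from compound 3 in one place: hydroxy in place of chloro on an aromatic carbon. Going by the values given here, no pair among the measured compounds isolates this exchange, so the expectation rests on the change itself and on where compound 3 stands. A group that carries a hydrogen-bond donor and acceptor replaces one that carries neither, and such a swap on a ring that matters this much is expected to move the number upward, toward a weaker inhibitor, by a step clearly beyond the scatter: a 14-fold higher number from compound 3 to compound 4 (1.15 log units; beyond the scatter). For compound 4 the estimate in this assay is 20 nM, with a likely range from 3 nM to 150 nM.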

Compound 4, half-maximal inhibitory concentration: 360 nM
Compound 4: the middle estimate sits 18-fold (1.26 log units) below what was measured, and the stated range ends below it.
By their numbers in this assay, from the lowest: compound 3; then compound 4; then compound 1; then compound 2.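

In this assay hydroxy in place of chloro on this aromatic carbon gives a 260-fold higher number from compound 3 to compound 4 (2.41 log units; beyond the scatter) and is a large step, the first here that isolates a single exchange. The position, meta to a cyano group, is therefore far from indifferent: only one heavy atom changed, the cyano group and the shared core stayed as they were, and most of the strength of compound 3 was lost. Nothing measured here explains why the exchange costs so much, and whether the hydroxy itself hurts or the chloro was what helped stays unsettled.

The compounds shown leave open whether other groups at this place, such as a fluoro, a methyl or an amine, would hold the low number of compound 3 or fall toward that of compound 4. Also open, as far as these compounds go, is how much the chloro depends on the cyano group, which a matching pair with a bromo or a methyl in place of the cyano group could begin to answer.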